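Amide variation on the shared core: cytotoxicity notes

The source may report more compounds than this note shows. Statements on the series, on what has been measured and on what is new or still open speak of the compounds shown alone.

Measured compounds:
compound 1 `COc1ccc(-c2cnc(NC(=O)c3cccnc3)n2C)cc1` — > 100000 nM
compound 2 `COc1ccc(-c2cnc(NC(=O)c3ccco3)n2C)cc1` — > 100000 nM
compound 3 `COc1ccc(-c2cnc(NC(=O)c3ccccc3)n2C)cc1` — > 100000 nM

Three amides of the shared core have been run in a toxicity assay on THP-1 cells (Homo sapiens) for inhibition; on this read-out lower numbers stand for higher toxicity in this test and higher numbers for lower toxicity in this test. In this assay compound 1 gives > 100000 nM, which is a limit of the assay and not a number. Compound 2 likewise gives > 100000 nM, again a limit. Compound 3 gives > 100000 nM, also a limit. The steps between them are therefore unreadable: a step that the two limits leave unreadable from compound 1 to compound 2 for furan-2-yl in place of pyridin-3-yl on a carbonyl carbon, a step that the two limits leave unreadable from compound 1 to compound 3 for phenyl in place of pyridin-3-yl on a carbonyl carbon, and a step that the two limits leave unreadable from compound 2 to compound 3 for phenyl in place of furan-2-yl on a carbonyl carbon. Compound 3 thus stands where every measured compound stands, at the limit of > 100000 nM in this assay, at which 3 of the 3 values shown sit; none of the three is separated from another.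

Compound 4 `CCCC(=O)Nc1ncc(-c2ccc(OC)cc2)n1C` is not yet measured. It differs from compound 3 by propyl in place of phenyl on a carbonyl carbon. Among the compounds with values here, none of the three measured steps carries a readable size for a change at the carbonyl carbon, and none concerns a chain in place of a ring; they show only that three aromatic groups on the carbonyl carbon leave the limit untouched. No step beyond the scatter is therefore expected; the step is estimated at a step that the limit leaves unreadable from compound 3 to compound 4. Compound 4 is expected to give 150000 nM in this assay, within 50000 nM to 500000 nM, and most likely to be reported again only as a limit.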

Compound 4, half-maximal cytotoxic concentration: > 100000 nM
Compound 4: only a limit was reported (the forecaster's own chance of this, stated with the estimate: 85%); the middle value is on the limit's open side.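

In this assay compound 4 gives > 100000 nM which is a limit of the assay and not a number. The steps to compound 4 from compound 1, compound 2 and compound 3 cannot be read, and all four compounds rest at one limit: the limit of > 100000 nM in this assay, at which 4 of the 4 values shown sit. Still open, going by these compounds, is whether any group on the carbonyl carbon of the shared core gives a readable value.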